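Gain Expected from a Benzyl Group Entering Compound 2

A few compounds are considered here, and "the series" means these few. Any claim that something is new, unique, unknown or untested is made for them only; others in the source may bear on it.

Measured compounds:
- compound 1 `CN(CCCN1CCCCC1)c1ccc(C(=O)N2CCc3ccc(OS(N)(=O)=O)cc3C2)cc1`: 40.7%
- compound 2 `NS(=O)(=O)Oc1ccc2c(c1)CN(C(=O)c1cccc(N3CCCCC3)c1)CC2`: 11.9%
- compound 3 `CCCN(Cc1ccccc1)c1ccc(C(=O)N2CCc3ccc(OS(N)(=O)=O)cc3C2)cc1`: 94.3%

In an assay on HEK293 cells for inhibition of Steryl-sulfatase (Homo sapiens), tested at 1 uM (a higher number here means a stronger effect of the compound at the concentration tested, a lower number a weaker effect), compound 2 gives the lowest of the three numbers; compound 1 is closest to it, and compound 3 lies far above it. Compound 4 `CCN(Cc1ccccc1)c1cccc(C(=O)N2CCc3ccc(OS(N)(=O)=O)cc3C2)c1` is not yet measured and differs from compound 2 as follows: benzyl(ethyl)amino in place of piperidin-1-yl on an aromatic carbon. Going by the values given here, one measured step bears on this change: a number 53.6 percentage points higher from compound 1 to compound 3 (beyond the scatter), where an amine carrying a benzyl group replaced another amino group and the number rose strongly. Compound 2 does not carry the same starting group, but the entering benzyl(ethyl)amino group closely resembles the benzyl(propyl)amino group of compound 3, so a rise beyond the scatter is expected. Compound 4 is estimated at 60%, within 30% to 90%, an expected step of a number 48.1 percentage points higher from compound 2 to compound 4 (beyond the scatter).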

Compound 4, a percentage reported as inhibition, at one concentration (the size of the read-out at that concentration, not a potency): 69%
For compound 4 the middle estimate is 9 percentage points below the measured one, and the stated range covers the measured number.
By their numbers in this assay, from the lowest: compound 2; then compound 1; then compound 4; then compound 3.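

In this assay, benzyl(ethyl)amino in place of piperidin-1-yl, on an aromatic carbon meta to a large group, gives a number 57.1 percentage points higher from compound 2 to compound 4 (beyond the scatter). An amine carrying a benzyl group therefore raises the number at this place too, and it does so when it replaces a plain piperidin-1-yl ring rather than the longer amino group of compound 1. No measurement shown here explains this rise. From the compounds shown here alone, whether the gain comes from the benzyl group or from the ethyl chain stays open. A plain ethylamino or benzylamino group at this place would separate the two.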